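Taking the Methoxy Group Off Compound 2

A few compounds are considered here, and "the series" means these few. Any claim that something is new, unique, unknown or untested is made for them only; others in the source may bear on it.

Measured compounds:
compound 1, `C/C(=N\O)c1ccc(NC(=O)CSc2nnc(-c3ccccc3)n2-c2ccccc2)cc1`, 63%
compound 2, `CCn1c(SCC(=O)Nc2ccc(/C(C)=N/O)cc2)nnc1-c1ccc(OC)cc1`, 60%

Both compounds were tested in a functional assay on the whole organism (strain albino) for inhibition, with Rattus norvegicus as the target, read by paw edema, with stated times of 30 min and 3 h, at a dose of 0.28 mmol/kg by the oral route; a lower number here means less inhibition, a higher number more inhibition at the dose given (going by the name of the read-out). Compound 1 gives 63% and compound 2 gives 60%, which is the lower of the two numbers, but the gap between them lies within the scatter of repeated measurements, so the two cannot be told apart. Compound 2 is the starting point for the next compound, compound 3, `CCn1c(SCC(=O)Nc2ccc(/C(C)=N/O)cc2)nnc1-c1ccccc1`. The change from compound 2 to compound 3 is hydrogen in place of methoxy on an aromatic carbon. Among the compounds with values here, no pair of measured compounds differs in only one place, so there is no measured step to lean on. The two measured compounds, which differ in more than one place, sit within the scatter of each other, and this gives no sign that the shared core reacts strongly to changes at its edges. The step from compound 2 to compound 3 is therefore expected to be small, a number 2 percentage points lower from compound 2 to compound 3 (within the scatter), not beyond the scatter in either direction. Compound 3 is expected to give about 58%, with a likely range from 45% to 70%.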

Compound 3, a percentage reported as inhibition, in the whole organism at one dose (the size of the read-out at that dose, not a potency): 65%
For compound 3 the middle estimate is 7 percentage points below the measured one; low and high end bracket the measured number.
By their numbers in this assay, from the lowest: compounds 2, 1 and 3 (each within the scatter of the next).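

In this assay, within the data shown here, exchanging methoxy for hydrogen, which turns 4-methoxyphenyl into phenyl, gives a number 5 percentage points higher from compound 2 to compound 3 (within the scatter) and thus provides the first measured single change at this position, one too small to tell the two compounds apart. Compound 3 also opens a second single comparison, ethyl in place of phenyl on an aromatic nitrogen, and this gives a number 2 percentage points higher from compound 1 to compound 3 (within the scatter) so that a change at a second place likewise leaves the inhibition of paw swelling at this dose indistinguishable. Nothing measured here explains why either step stays so small.

From the compounds shown here alone, whether an amine or a carboxylic acid in place of the hydrogen on the aromatic carbon, or a longer chain such as butyl in place of the ethyl on the aromatic nitrogen, would move the number beyond the usual scatter remains open. Also open, going by these compounds, is whether these compounds would still be indistinguishable at other doses, given that each figure reports the size of the effect at a single dose and not a potency.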